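Removing the ring methyl from a morpholine side chain

The compounds below may be only part of what the source reports. "The series", "measured", "known", "first", "only" and "open" are said of these compounds alone.

Compounds measured so far:
- compound 1, `Cc1cc(Cl)cc(-c2ccnc3cc(CN4C(=O)C5CC5C4=O)sc23)c1C[C@@H]1CNC[C@@H](C)O1`: 0.39 nM
- compound 2, `Cc1cc(Cl)cc(-c2ccnc3cc(CN4C(=O)C5C(C4=O)C5(C)C)sc23)c1NC1CCCNC1`: 0.78 nM

Both compounds share the same core and were tested in an assay on isolated protein for inhibition of ubiquitin carboxyl-terminal hydrolase 7 (Homo sapiens), read by fluorescence, with stated times of 30 min and 1 h; on this read-out higher numbers stand for weaker inhibition and lower numbers for stronger inhibition. In this assay compound 1 gives 0.39 nM, and compound 2 gives 0.78 nM. The two numbers lie within the scatter of each other, so neither compound can be set apart from the other on this evidence; compound 1 simply stands as one of a close pair.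

Compound 3, `Cc1cc(Cl)cc(-c2ccnc3cc(CN4C(=O)C5CC5C4=O)sc23)c1C[C@@H]1CNCCO1`, has not yet been measured. It differs from compound 1 in one place: hydrogen in place of methyl on a saturated ring carbon. Among the measured compounds shown here, no measured pair shows what this change does, so the step can only be estimated from the structures themselves. A single small group leaving a saturated ring position, with nothing entering, is expected to move the number little in this assay, if at all beyond the scatter, with a slight lean towards a higher number.

For compound 3 the expected step is a 1.5-fold higher number from compound 1 to compound 3 (0.19 log units; within the scatter), giving an estimate of 0.6 nM with a range from 0.25 nM to 1.5 nM.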

Compound 3, half-maximal inhibitory concentration: 0.16 nM
Estimate against measurement, compound 3: 3.8-fold (0.57 log units) above; measured number outside the range, below it.
By their numbers in this assay, from the lowest: compound 3; then compounds 1 and 2 (each within the scatter of the next).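

On the saturated ring carbon next to the ring oxygen, going from 6-methylmorpholin-2-yl to morpholin-2-yl gives a 2.4-fold lower number from compound 1 to compound 3 (0.39 log units; beyond the scatter) in this assay, so the methyl is not required for the very low numbers seen with compound 1. The step is modest but lies beyond the scatter, which means that at this one position, hydrogen gives stronger inhibition than methyl. Compounds 1 and 2 could not show this, as they differ in more than one place, while compounds 1 and 3 differ only in this methyl, and nothing measured here bears on why the number falls when it leaves.

As far as these compounds go, this single pair speaks only for methyl against hydrogen, so it remains open how an ethyl group, a fluorine atom or a hydroxyl group on the same carbon would behave in this assay. From the compounds shown here alone, it also remains open whether removing a methyl would give a similar step with a different group on the rest of the molecule, such as the amine-linked side chain of compound 2.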